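Methoxy in Place of Bromo: an Estimate for Compound 4

The compounds below may be only part of what the source reports. "The series", "measured", "known", "first", "only" and "open" are said of these compounds alone.

Compound 1, `COC(=O)[C@@]1(C)CCC=C2[C@@H]1CC[C@@H](C)[C@]2(C)Cc1c[nH]c2ccc(Br)cc12`: in a functional assay on A549 cells (Homo sapiens) for inhibition, read by sulforhodamine B assay, with a stated time of 48 h (a higher number here means a weaker inhibitor of growth, a lower number a stronger inhibitor of growth), compound 1 gives 15000 nM.
Compound 2, `COC(=O)[C@@]1(C)CCC=C2[C@@H]1CC[C@@H](C)[C@]2(C)Cc1c[nH]c2ccc(OC)cc12`: compound 2 gives 2200 nM.
Compound 3, `COC(=O)[C@@]1(C)CCC=C2[C@@H]1CC[C@@H](C)[C@]2(C)Cc1c(C)[nH]c2ccc(Br)cc12`: compound 3 gives 15000 nM.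

Compound 3 stands level with compound 1 at the digits shown, and the two together hold the highest numbers of the three; the nearest neighbour is compound 1, no change at the digits printed from compound 1 to compound 3 (within the scatter), while compound 2 lies furthest away with its lower value.

Compound 4, `COC(=O)[C@@]1(C)CCC=C2[C@@H]1CC[C@@H](C)[C@]2(C)Cc1c(C)[nH]c2ccc(OC)cc12`, differs from compound 3 by methoxy in place of bromo on an aromatic carbon. Within the data shown here, the one measured step that bears on this is the same exchange made on compound 1, a 6.8-fold lower number from compound 1 to compound 2 (0.83 log units; beyond the scatter), a modest but real drop. Since the added methyl changed nothing, no change at the digits printed from compound 1 to compound 3 (within the scatter), a downward step of similar size in this assay is expected. For compound 4 the expected step is a 6.8-fold lower number from compound 3 to compound 4 (0.83 log units; beyond the scatter). Compound 4 is therefore estimated at 2200 nM, within 900 nM to 6000 nM.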

Compound 4, concentration for 50% growth inhibition: 16000 nM
The estimate for compound 4 lay 7.3-fold (0.86 log units) below the measured number, and the stated range ends below it.
By their numbers in this assay, from the lowest: compound 2; then compounds 1, 3 and 4 (each within the scatter of the next).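

With the methyl present, methoxy in place of bromo gives a 1.1-fold higher number from compound 3 to compound 4 (0.03 log units; within the scatter), so the gain seen on the core of compound 1 does not carry over: the same change on two cores in this assay, a 6.8-fold lower number (0.83 log units; beyond the scatter) from compound 1 to compound 2 and a 1.1-fold higher number (0.03 log units; within the scatter) from compound 3 to compound 4, 7.3-fold (0.86 log units) apart, beyond the scatter of two such steps. Methyl in place of hydrogen, silent on the bromo compounds, gives a 7.3-fold higher number from compound 2 to compound 4 (0.86 log units; beyond the scatter) on the methoxy compounds: the same change on two cores in this assay, no change at the digits printed (within the scatter) from compound 1 to compound 3 and a 7.3-fold higher number (0.86 log units; beyond the scatter) from compound 2 to compound 4, 7.3-fold (0.86 log units) apart, beyond the scatter of two such steps. The two changes therefore do not add independently, and among these compounds only compound 2, with methoxy and without the methyl, has the lower number.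

The compounds shown carry only bromo or methoxy at this aromatic carbon. From the compounds shown here alone, whether a hydroxyl or an amine there would depend on the methyl in the same way remains open.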